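Trifluoromethyl for Chloro on a Fluorinated Anilide Core

This account rests on a few compounds, and the source may have more. Where it says the series, first, only, none or still open, it means among the compounds named here.

Compound 1 `O=C(Nc1ccc(Oc2ccnc3[nH]ccc23)cc1)c1cc(-c2ccc(Cl)cc2)ncn1` and compound 2 `O=C(Nc1ccc(Oc2ccnc3[nH]ccc23)cc1)c1cc(-c2ccc(C(F)(F)F)cc2)ncn1` share one core. In a functional assay on A549 cells (Homo sapiens) for cytotoxicity, read by MTT assay, with a stated time of 72 h (a higher number here means a weaker inhibitor, a lower number a stronger inhibitor), compound 1 gives 6530 nM and compound 2 gives 9380 nM. The change between them is trifluoromethyl in place of chloro on an aromatic carbon, and it made a step of a 1.4-fold higher number from compound 1 to compound 2 (0.16 log units; within the scatter). Compound 3 `O=C(Nc1ccc(Oc2ccnc3[nH]ccc23)c(F)c1)c1cc(-c2ccc(Cl)cc2)ncn1` differs from compound 1 by fluoro in place of hydrogen on an aromatic carbon; in this assay compound 3 gives 3360 nM, a step of a 1.9-fold lower number from compound 1 to compound 3 (0.29 log units; within the scatter). Compound 4 `O=C(Nc1ccc(Oc2ccnc3[nH]ccc23)c(F)c1)c1cc(-c2ccc(C(F)(F)F)cc2)ncn1` has not yet been measured. It differs from compound 3 by trifluoromethyl in place of chloro on an aromatic carbon, the same change as that made from compound 1 to compound 2, now on the core of compound 3. Compound 4 is expected to show a step of a 1.4-fold higher number from compound 3 to compound 4 (0.15 log units; within the scatter), because the same change earlier gave a 1.4-fold higher number from compound 1 to compound 2 (0.16 log units; within the scatter). The estimate for compound 4 in this assay is 4700 nM, within a range from 2500 nM to 9000 nM.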

Compound 4, half-maximal inhibitory concentration: 2220 nM
Compound 4: the middle estimate sits 2.1-fold (0.33 log units) above what was measured; the measured number lies below the stated range.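

Trifluoromethyl in place of chloro made a 1.5-fold lower number from compound 3 to compound 4 (0.18 log units; within the scatter) in this assay, and this step and the earlier one on the core of compound 1 lie within the scatter and do not differ from each other beyond it: the same change on two cores in this assay, a 1.4-fold higher number (0.16 log units; within the scatter) from compound 1 to compound 2 and a 1.5-fold lower number (0.18 log units; within the scatter) from compound 3 to compound 4, 2.2-fold (0.34 log units) apart, within the scatter of two such steps. Fluoro in place of hydrogen, now on the trifluoromethyl compounds, made a 4.2-fold lower number from compound 2 to compound 4 (0.63 log units; beyond the scatter), which is beyond the scatter, yet it cannot be told apart from the step on the chloro compounds: the same change on two cores in this assay, a 1.9-fold lower number (0.29 log units; within the scatter) from compound 1 to compound 3 and a 4.2-fold lower number (0.63 log units; beyond the scatter) from compound 2 to compound 4, 2.2-fold (0.34 log units) apart, within the scatter of two such steps. Both changes thus carried across these two cores without a detectable difference, but two cores do not show that the steps are equal in size or that they hold elsewhere in the series.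

The compounds shown leave open what a nitrile, a methoxy group or an amine would do in place of chloro in this assay.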